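Iodo in place of chloro on compound 3

A few compounds are considered here, and "the series" means these few. Any claim that something is new, unique, unknown or untested is made for them only; others in the source may bear on it.

Measured in a functional assay on L1210 cells (Mus musculus) for antiproliferative activity, read by cell counting, with a stated time of 48 h; on this read-out higher numbers stand for weaker inhibition and lower numbers for stronger inhibition:
- compound 1 `C#C[C@@]1(O)[C@@H](CO)O[C@@H](n2cc(Cl)c3c(Cl)ccnc32)[C@@H]1O`: 75000 nM
- compound 2 `C#C[C@@]1(O)[C@@H](CO)O[C@@H](n2cc(I)c3c(Cl)ccnc32)[C@@H]1O`: 20000 nM
- compound 3 `C#C[C@@]1(O)[C@@H](CO)O[C@@H](n2cc(Cl)c3c(N)ccnc32)[C@@H]1O`: 980 nM

Of these three, compound 3, at 980 nM, carries the lowest number and so shows the strongest inhibition, clear of the scatter against both others. It got there through a large step, a 77-fold lower number from compound 1 to compound 3 (1.88 log units; beyond the scatter), with amino in place of chloro on an aromatic carbon.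

The next compound, compound 4 `C#C[C@@]1(O)[C@@H](CO)O[C@@H](n2cc(I)c3c(N)ccnc32)[C@@H]1O`, has not yet been measured. It differs from compound 3 as follows: iodo in place of chloro on an aromatic carbon. The same kind of exchange, iodo in place of chloro on an aromatic carbon, has been measured once, as a 3.8-fold lower number from compound 1 to compound 2 (0.57 log units; beyond the scatter). That modest step, beyond the scatter, is the closest guide, and it points towards a lower number. The amino step bears on the change only by setting the starting point. Whether the iodo gain holds in the presence of the amino group is something the data do not show, so the range is kept wide. What is expected is a 3.4-fold lower number from compound 3 to compound 4 (0.53 log units; beyond the scatter). For compound 4 the estimated value is 290 nM, with an expected range of 80 nM to 1000 nM.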

Compound 4, half-maximal inhibitory concentration: 44 nM
Estimate against measurement, compound 4: 6.6-fold (0.82 log units) above; measured number outside the range, below it.
By their numbers in this assay, from the lowest: compound 4; then compound 3; then compound 2; then compound 1.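

In this assay, the exchange of chloro for iodo on this aromatic carbon, two ring bonds from the ring nitrogen, turns out not to have one fixed size. With the amino group present it gives a 22-fold lower number from compound 3 to compound 4 (1.35 log units; beyond the scatter), far more than it gave with chloro in that other place, so the two steps do not agree: the same change on two cores in this assay, a 3.8-fold lower number (0.57 log units; beyond the scatter) from compound 1 to compound 2 and a 22-fold lower number (1.35 log units; beyond the scatter) from compound 3 to compound 4, 5.9-fold (0.77 log units) apart, beyond the scatter of two such steps. The amino exchange shows the same dependence from the other side, reaching a 450-fold lower number from compound 2 to compound 4 (2.66 log units; beyond the scatter) once iodo is present, so across these four compounds the two changes do not add up independently, and each is worth more in the presence of the other: the same change on two cores in this assay, a 77-fold lower number (1.88 log units; beyond the scatter) from compound 1 to compound 3 and a 450-fold lower number (2.66 log units; beyond the scatter) from compound 2 to compound 4, 5.9-fold (0.77 log units) apart, beyond the scatter of two such steps.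

As far as these compounds go, how bromo or a methyl group on this same carbon would fit, and whether a methylamino group in place of the amino group would keep the same coupling with iodo, remains open. The numbers give the size of this coupling but not its cause.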